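The source may report more compounds than this note shows. Statements on the series, on what has been measured and on what is new or still open speak of the compounds shown alone.

Compound 1, `COc1ccc(Nc2ncnc3cc(OC)c(OCCCCC(=O)Nc4ccc(S(N)(=O)=O)cc4)cc23)cc1`, in a functional assay on A-431 cells (Homo sapiens) for antiproliferative activity, read by MTT assay, with a stated time of 72 h (a higher number here means a weaker inhibitor, a lower number a stronger inhibitor), gives 14700 nM.
Compound 2, `NS(=O)(=O)c1ccc(NC(=S)Nc2ccc3ncnc(Nc4cccc(C(F)(F)F)c4)c3c2)cc1`, in this assay gives 21700 nM.

Among the measured compounds shown here, of these two numbers, compound 2 holds the higher one, but its only neighbour, compound 1, sits so close that the gap between them falls within the usual scatter of this assay, and no order can be read from it. Both compounds are weak inhibitors of proliferation in this cell line.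

Compound 3, `CCc1ccc(Nc2ncnc3ccc(NC(=S)Nc4ccc(S(N)(=O)=O)cc4)cc23)cc1`, has not yet been measured in this assay. It is built on the same core as compound 2 and differs from it in one place: 4-ethylphenyl in place of 3-(trifluoromethyl)phenyl on a nitrogen on an aromatic ring. For the measured compounds named here, no measured pair of compounds shows this particular change, so there is no measured step to lean on, and the expectation rests only on the value of compound 2 in this assay and on the smallness of the change.

The step is expected to be small, a 1.2-fold higher number from compound 2 to compound 3 (0.06 log units; within the scatter), with no direction beyond the scatter. For compound 3 the estimate in this assay is 25000 nM, within a range from 8000 nM to 80000 nM.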

Compound 3, half-maximal inhibitory concentration: 38400 nM
Compound 3: the middle estimate sits 1.5-fold (0.19 log units) below what was measured; the range from low to high includes it.
By their numbers in this assay, from the lowest: compounds 1, 2 and 3 (each within the scatter of the next, the first and the last beyond it).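

In this assay, among the compounds shown here, the exchange of 3-(trifluoromethyl)phenyl for 4-ethylphenyl on a nitrogen on an aromatic ring gives a 1.8-fold higher number from compound 2 to compound 3 (0.25 log units; within the scatter), the first reading of any change at this position. A group of 10 heavy atoms that carries fluorine and a group of 8 heavy atoms that is carbon only thus cannot be told apart here, and compound 3, at 38400 nM, remains a weak inhibitor of proliferation in this cell line, as does compound 2, at 21700 nM. No measurement is at hand that would explain how these two groups compare on the shared core.

Going by these compounds, what stays open is whether a substituent of a different kind on this phenyl ring, such as an amine, a carboxylic acid or a longer chain in place of the ethyl, would bring the number down beyond the scatter. Also open, on these data alone, is how much the identity of the substituent and its place on the ring each contribute, since these two things change together in this single step.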